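The source may hold more compounds than are shown below. What is called first, only, known or untested is meant among the compounds shown, and "the series" means these compounds.

Measured in a functional assay on T47D cells (Homo sapiens) for antiproliferative activity, read by MTT assay, with a stated time of 72 h; a higher number here means a weaker inhibitor, a lower number a stronger inhibitor:
- compound 1 `CCn1ccnc1-c1cc(OC)c(OC)c(OC)c1`: > 100000 nM
- compound 2 `CCCCCn1ccnc1-c1cc(OC)c(OC)c(OC)c1`: 64400 nM

The entry for compound 1 is a limit of the assay and not a number, and compound 1 sits at the limit of > 100000 nM in this assay, at which 1 of the 2 values shown sits. Going by the values given here, compound 2, at 64400 nM, therefore holds the only true number, so it cannot yet be ranked with any precision.

Next is compound 3 `COc1cc(-c2nccn2-c2ccc(F)cc2)cc(OC)c1OC`, with 4-fluorophenyl in place of pentyl on an aromatic nitrogen. Among the compounds with values here, the one measured step, an at least 1.5-fold lower number from compound 1 to compound 2 (0.19 log units; that floor lies within the scatter), only lengthens a chain and brings in no ring, so it bears on this change only weakly. No step beyond the scatter is therefore expected in this assay, though with wide uncertainty and a slight lean towards a lower number. The expected step is a 1.3-fold lower number from compound 2 to compound 3 (0.11 log units; within the scatter). The estimate for compound 3 is 50000 nM, with an expected range from 12000 nM to 100000 nM.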

Compound 3, half-maximal inhibitory concentration: > 100000 nM
Compound 3 was reported as a limit (the forecaster's own chance of this, stated with the estimate: 35%); at least 2.0-fold (0.30 log units) between middle value and limit.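

In this assay the entry for compound 3 is a limit and not a number. Putting 4-fluorophenyl in place of pentyl on the aromatic nitrogen gives an at least 1.5-fold higher number from compound 2 to compound 3 (0.19 log units; that floor lies within the scatter), so this aromatic ring brings no gain over the pentyl chain, although the size of any loss cannot be told. The step from compound 1 to compound 3 cannot be read, and compound 2 remains the only compound with a true number, since the assay limit now holds most of the series: the limit of > 100000 nM in this assay, at which 2 of the 3 values shown sit.

On these data alone, whether a longer chain such as octyl on the aromatic nitrogen would lower the number further remains open. So does whether a benzyl group there would behave more like pentyl or like 4-fluorophenyl.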